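The source may report more compounds than this note shows. Statements on the series, on what has been measured and on what is new or still open speak of the compounds shown alone.

Compounds measured so far:
compound 1 `Nc1scc(-c2ccccc2)c1C(=O)c1ccccc1`: 48%
compound 2 `Nc1scc(-c2cccc(F)c2)c1C(=O)c1ccccc1`: 52%
compound 3 `Nc1scc(-c2ccc(Cl)cc2)c1C(=O)c1ccccc1`: 51%

All three were tested in a functional assay on CHO cells for agonist activity at adenosine receptor A1 (Homo sapiens), read by fluorescence and ERK phosphorylation, with stated times of 30 min and 1.5 h, tested at 10 uM; a higher number here means a stronger effect of the compound at the concentration tested, a lower number a weaker effect. Compound 2 holds the highest of the three numbers, but the gaps are small: a number 4 percentage points higher from compound 1 to compound 2 (within the scatter) and a number 1 percentage points lower from compound 2 to compound 3 (within the scatter), so none of the three can be set apart from the others.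

Compound 4 `Nc1scc(-c2cccc(F)c2)c1C(=O)c1ccc(Cl)cc1` is not yet measured. It differs from compound 2 in one place: chloro in place of hydrogen on an aromatic carbon. The change is made on the shared core of compound 2, leaving the 3-fluorophenyl ring untouched.

Among the compounds with values here, two measured steps bear on this change. The closest is a chloro in place of hydrogen on an aromatic carbon, a number 3 percentage points higher from compound 1 to compound 3 (within the scatter). The other adds a single halogen in the same way, a number 4 percentage points higher from compound 1 to compound 2 (within the scatter). Both stayed within the scatter, so a step within the scatter is expected again, with no clear direction, for compound 4 in this assay.

Compound 4 is therefore expected to give 52%, within a range of 40% to 64%, which means an expected step of no change at the digits printed from compound 2 to compound 4 (within the scatter).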

Compound 4, a percentage reported as activity, at one concentration (the size of the read-out at that concentration, not a potency): 90%
Beside the measured number, compound 4's estimate is 38 percentage points below it; measured number outside the range, above it.
By their numbers in this assay, from the lowest: compounds 1, 3 and 2 (each within the scatter of the next); then compound 4.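

In this assay, within the data shown here, the phenyl to 4-chlorophenyl change on the phenyl attached to the carbonyl of compound 2 is the first single change here to go beyond the scatter: a number 38 percentage points higher from compound 2 to compound 4 (beyond the scatter). The earlier halogen changes were all made on the other phenyl ring, so they gave no information about how the read-out responds to a change on this one. The result also shows that the name of a change does not fix its effect, since swapping hydrogen for chloro gave very different results in the two settings: the same change on two cores in this assay, a number 3 percentage points higher (within the scatter) from compound 1 to compound 3 and a number 38 percentage points higher (beyond the scatter) from compound 2 to compound 4, 35 percentage points apart, beyond the scatter of two such steps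

The compounds shown leave open whether a bromo, a methyl, a methoxy or an amine at this position would raise the number as the chloro does, and whether the gain depends on the 3-fluorophenyl ring of compound 2 or would also appear with the unsubstituted phenyl ring of compound 1. The read-out is also taken at a single concentration, so it gives the size of the effect there and leaves the potency of compound 4 unknown.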